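Fluoro at the Phenoxy Ring of a Bromocoumarin Triazole

The source may report more compounds than this note shows. Statements on the series, on what has been measured and on what is new or still open speak of the compounds shown alone.

The measured compounds:
compound 1, `O=c1cc(-n2cc(COc3ccccc3)nn2)c2cc(Br)ccc2o1`, 12300 nM
compound 2, `O=c1cc(-n2cc(COc3ccccc3O)nn2)c2cc(Br)ccc2o1`, 7940 nM
compound 3, `O=c1cc(-n2cc(COc3ccc(C(F)(F)F)cc3)nn2)c2cc(Br)ccc2o1`, 1620 nM

In a functional assay on A549 cells (Homo sapiens) for antiproliferative activity, read by MTT assay, with a stated time of 48 h (on this read-out higher numbers stand for weaker inhibition and lower numbers for stronger inhibition), compound 1 gives the highest number of the three, 12300 nM. Compound 2 sits closest to it, and the step of a 1.5-fold lower number from compound 1 to compound 2 (0.19 log units; within the scatter) stays within the scatter, so the two cannot be ordered. Compound 3 lies furthest away, and the step of a 7.6-fold lower number from compound 1 to compound 3 (0.88 log units; beyond the scatter) is beyond the scatter.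

Compound 4, `O=c1cc(-n2cc(COc3ccc(F)cc3)nn2)c2cc(Br)ccc2o1`, has not yet been measured in this assay. It differs from compound 1 by fluoro in place of hydrogen on an aromatic carbon. Within the data shown here, of the two measured steps, the one from compound 1 to compound 3 bears most on this change, because a 7.6-fold lower number from compound 1 to compound 3 (0.88 log units; beyond the scatter) concerns a substituent entering at the same aromatic position of the phenoxy ring, though that entering group was trifluoromethyl rather than fluoro. The step to compound 2 puts hydroxy at a different position of the ring and is within the scatter, so it carries little weight here.

Compound 4 is therefore expected to show a number below compound 1 but not as low as compound 3, an estimated step of a 2.5-fold lower number from compound 1 to compound 4 (0.39 log units; beyond the scatter). The estimate for compound 4 in this assay is 5000 nM, within a range from 2000 nM to 12000 nM.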

Compound 4, half-maximal inhibitory concentration: 850 nM
The estimate for compound 4 lay 5.9-fold (0.77 log units) above the measured number; the whole stated range lies above it.
By their numbers in this assay, from the lowest: compounds 4 and 3 (each within the scatter of the next); then compounds 2 and 1 (each within the scatter of the next).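

In this assay, a single fluoro on the phenoxy ring, para to a large group, is enough for a large change: a 14-fold lower number from compound 1 to compound 4 (1.16 log units; beyond the scatter). The effect at this position is therefore not confined to trifluoromethyl, and the two groups cannot be ordered, as the step of a 1.9-fold lower number from compound 3 to compound 4 (0.28 log units; within the scatter) stays within the scatter. The 4-fluorophenyl group also stands apart from the 2-hydroxyphenyl group, with a 9.3-fold lower number from compound 2 to compound 4 (0.97 log units; beyond the scatter), but that step changes both the substituent and its place on the ring, so it cannot show which of the two matters.

No supporting information is available to explain why so small a replacement for hydrogen comes with so large a step. The compounds shown leave open whether other groups at this position, such as chloro, methoxy, an amine or a carboxylic acid, would follow fluoro and trifluoromethyl, and whether fluoro elsewhere on the phenoxy ring or hydroxy at this same position would give a comparable number.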